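This account rests on a few compounds, and the source may have more. Where it says the series, first, only, none or still open, it means among the compounds named here.

Compound 3, `COc1cc(-c2nn(-c3cccc(NC(=O)Nc4cccc(C(F)(F)F)c4)c3)cc2-c2ccncc2)ccc1Cl`, gives 3960 nM in a functional assay on SK-MEL-2 cells (Homo sapiens) for inhibition, read by sulforhodamine B assay, with a stated time of 48 h; on this read-out lower numbers stand for higher toxicity in this test and higher numbers for lower toxicity in this test. Among the two numbers at hand it is the lowest, but its nearest neighbour, compound 2, `COc1cc(-c2nn(-c3cccc(NC(=O)Nc4ccc(Cl)c(Cl)c4)c3)cc2-c2ccncc2)ccc1Cl`, gives 4850 nM in this assay, and the step of a 1.2-fold lower number from compound 2 to compound 3 (0.09 log units; within the scatter) lies within the scatter, so the two cannot be ordered. Compound 1, `COc1cc(-c2nn(-c3cccc(NC(=O)c4cccc(C(F)(F)F)c4)c3)cc2-c2ccncc2)ccc1Cl`, is reported in this assay only as a limit, > 50000 nM. Compound 4, `COc1cc(-c2nn(-c3cccc(NC(=O)c4ccc(Cl)c(C(F)(F)F)c4)c3)cc2-c2ccncc2)ccc1Cl`, has not been measured in this assay. The change that leads to it is 4-chloro-3-(trifluoromethyl)phenyl in place of (3-(trifluoromethyl)phenyl)amino on a carbonyl carbon; the amide-type nitrogen of the urea in compound 3 is thereby lost and the carbonyl carries the aryl group directly, as in compound 1. Going by the values given here, the steps that bear on this are the reverse of those already seen: an at least 12-fold lower number from compound 1 to compound 3 (1.10 log units; beyond the scatter) and an at least 10-fold lower number from compound 1 to compound 2 (1.01 log units; beyond the scatter), both large and both running toward a lower number when the (arylamino) group entered on the carbonyl carbon, with compound 1 sitting at the limit (the limit of > 50000 nM in this assay, at which 1 of the 3 values shown sits). Compound 4 is therefore expected to move back toward a higher number, by a step estimated as a 10-fold higher number from compound 3 to compound 4 (1.00 log units; beyond the scatter), and it may well reach the limit again. Compound 4 is estimated at 40000 nM, with a range from 10000 nM to 120000 nM.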

Compound 4, concentration lethal to 50% of the cells: > 32500 nM
Compound 4: no number, only a limit; the forecaster's own chance of this, stated with the estimate: 60%; the middle value lies beyond the limit too.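

In this assay, putting 4-chloro-3-(trifluoromethyl)phenyl in place of (3-(trifluoromethyl)phenyl)amino on the carbonyl carbon gives an at least 8.2-fold higher number from compound 3 to compound 4 (0.91 log units; beyond the scatter), and the same kind of exchange starting from the dichlorophenyl urea gives an at least 6.7-fold higher number from compound 2 to compound 4 (0.82 log units; beyond the scatter). The earlier compounds showed the gap between an aryl group and an arylamino group on this carbonyl carbon only with the 3-(trifluoromethyl)phenyl group of compound 1, whereas it now also holds for an aryl group that carries a chloro, and among the four compounds shown none goes against it. As with compound 1, however, the result for compound 4 is a limit and not a number: the limit of > 32500 nM in this assay, at which 1 of the 4 values shown sits.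

On these data alone, the step between compound 1 and compound 4 cannot be read, so what chloro in place of hydrogen on an aromatic carbon does in this amide pair stays open. Also open, as far as these compounds go, is what the carbonyl carbon would give in this assay with a non-aromatic group such as a cyclohexylamino group, or with a longer chain such as benzylamino, where the amide-type nitrogen stays and the ring moves further from it.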